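Series notes: cytotoxicity readings and a fourth analogue

The source may hold more compounds than are shown below. What is called first, only, known or untested is meant among the compounds shown, and "the series" means these compounds.

In an ADME assay on Raji cells (Homo sapiens) for cytotoxicity, with a stated time of 72 h (a higher number here means that more compound is needed for the effect, a lower number that less compound is needed), the measured compounds stand as follows:
compound 1, `Cc1cc(NC(=O)Nc2cc(F)ccc2F)c2ccccc2n1`, gives > 25000 nM.
compound 2, `Cc1cc(NC(=O)Nc2ccccc2C(F)(F)F)c2ccccc2n1`, gives > 25000 nM.
compound 3, `Cc1cc(NC(=O)Nc2ccc(N)cc2)c2ccccc2n1`, gives > 25000 nM.

Each of these readings is a limit of the assay and not a number. Compound 3 therefore stands at the limit of > 25000 nM in this assay, at which 3 of the 3 values shown sit, with nothing separating it from the other two on the numbers shown, and no step between measured compounds can be sized.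

Compound 4 is `Cc1cc(NC(=O)Nc2ccccc2F)c2ccccc2n1`. Against compound 3 the change is 2-fluorophenyl in place of 4-aminophenyl on an amide-type nitrogen. With all three readings at the limit, the expectation for this assay is a step of none beyond the scatter, so that the expected step that the limit leaves unreadable from compound 3 to compound 4 should stay flat. Compound 4 is accordingly expected at 35000 nM, with a range from 12000 nM to 100000 nM, most likely again reported as a limit.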

Compound 4, half-maximal effective concentration: > 25000 nM
Compound 4 was reported as a limit; the forecaster's own chance of this, stated with the estimate: 85%; the middle value lies beyond the limit too.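

No step to compound 4 from compound 1, compound 2 or compound 3 can be read in this assay, since all four readings are limits and not numbers: the limit of > 25000 nM in this assay, at which 4 of the 4 values shown sit.

The compounds shown leave open at what concentration any of them reaches the half-maximal effect, and whether the groups exchanged on the amide-type nitrogen change it at all.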